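Ester for propyl on a triazole core

The compounds below may be only part of what the source reports. "The series", "measured", "known", "first", "only" and "open" are said of these compounds alone.

Measured so far:
compound 1 `COC(=O)c1cn(C/C=C(\C)CCC=C(C)C)nn1`, 3.2
compound 2 `CCCCCc1cn(C/C=C(/C)CCC=C(C)C)nn1`, 5.45
compound 3 `CCCc1cn(C/C=C(/C)CCC=C(C)C)nn1`, 4.05

In a physicochemical assay for lipophilicity, measured as octanol-water partition (a lower number here means a more polar compound, a higher number a more lipophilic compound), compound 3 stands second highest of the three numbers shown. Its nearest neighbour is compound 1, which gives 3.2; furthest is compound 2, which gives 5.45, both gaps beyond the scatter. Among the measured compounds shown here, the one measured step, a number 1.40 log units lower from compound 2 to compound 3 (beyond the scatter), shortens a chain on the core and is large.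

Compound 4 `COC(=O)c1cn(C/C=C(/C)CCC=C(C)C)nn1` differs from compound 3 as follows: methoxycarbonyl in place of propyl on an aromatic carbon. For the measured compounds named here, no measured step swaps a propyl for a methoxycarbonyl, so the only guide is compound 1, which carries the same methoxycarbonyl group on its core and gives 3.2. Because compound 1 gives 3.2, compound 4 is expected to land near it, at about 3.25, within 2.8 to 3.7. That estimate means a step of a number 0.80 log units lower from compound 3 to compound 4 (beyond the scatter) in this assay, downward and beyond the scatter.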

Compound 4, partition coefficient: 3.2
Compound 4: the middle estimate sits 0.05 log units above what was measured; the measured number falls inside the stated range.
By their numbers in this assay, from the lowest: compounds 1 and 4 (each within the scatter of the next); then compound 3; then compound 2.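

In this assay, methoxycarbonyl on this aromatic carbon now has a direct comparison with the alkyl chains at the same drawn configuration, giving a number 0.85 log units lower from compound 3 to compound 4 (beyond the scatter) and a number 2.25 log units lower from compound 2 to compound 4 (beyond the scatter). Among the compounds shown here, until now the only methoxycarbonyl compound had differed from the chain compounds in configuration as well, so this change could not be read alone. The double bond's drawn configuration makes no difference that this assay can detect in the methoxycarbonyl pair, with no change at the digits printed from compound 1 to compound 4 (within the scatter), and that reading rests on one point: the fact that compounds 1 and 4 differ only in the configuration as drawn

As far as these compounds go, whether the same holds with propyl or pentyl on the shared core remains open. So does where a carboxylic acid, an amide or an amine on this aromatic carbon would fall in this assay.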